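The source may report more compounds than this note shows. Statements on the series, on what has been measured and on what is new or still open speak of the compounds shown alone.

Compound 1 `C[C@H](NC(=O)c1nc(-c2ccccn2)nc(O)c1O)C1CCCCC1` - 600 nM
Compound 2 `Cc1ccnc(-c2nc(O)c(O)c(C(=O)N[C@H](C)C3CCCCC3)n2)c1` - 2700 nM

In an ADME assay on HeLa cells (Homo sapiens) for cytotoxicity (a higher number here means that more compound is tolerated, a lower number that less compound is tolerated), compound 2 gives 2700 nM as the higher of the two numbers and compound 1 gives 600 nM as the lower, a gap beyond the usual scatter. Compound 3 `C[C@@H](NC(=O)c1nc(-c2cc(Cl)ccn2)nc(O)c1O)C1CCCCC1` carries chloro in place of methyl on an aromatic carbon of compound 2 (chloro in place of methyl on an aromatic carbon), so that 4-methylpyridin-2-yl becomes 4-chloropyridin-2-yl. Among the measured compounds shown here, no measured pair isolates this swap, so only a small change is expected, and the estimated 1.4-fold lower number from compound 2 to compound 3 (0.13 log units; within the scatter) stays within the scatter. The value estimated for compound 3 is 2000 nM with an expected range of 700 nM to 6000 nM in this measurement.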

Compound 3, half-maximal cytotoxic concentration: 3000 nM
Beside the measured number, compound 3's estimate is 1.5-fold (0.18 log units) below it; low and high end bracket the measured number.
By their numbers in this assay, from the lowest: compound 1; then compounds 2 and 3 (each within the scatter of the next).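

In this assay, among the compounds shown here, the change from 4-methylpyridin-2-yl to 4-chloropyridin-2-yl gives a 1.1-fold higher number from compound 2 to compound 3 (0.05 log units; within the scatter) and so provides the first measured pair that isolates a change at this position. On this pair, chloro and methyl on this aromatic carbon cannot be told apart by their numbers. No measurement shown offers an explanation for this result. Going by these compounds, whether a methoxy group, an amine or a carboxylic acid on the same carbon would also leave the number unchanged stays open. So does whether this swap would read the same with a different amide side chain.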